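Urea series: fluoro to amino on the phenyl ring

This account rests on a few compounds, and the source may have more. Where it says the series, first, only, none or still open, it means among the compounds named here.

Measured so far:
compound 1 `Cc1cc(NC(=O)Nc2ccc(F)cc2)c2ccccc2n1`: 801 10^-6 cm/s
compound 2 `Cc1cc(NC(=O)Nc2ccc(F)cc2F)c2ccccc2n1`: 640 10^-6 cm/s

Notes. In an ADME assay for permeability, using PAMPA, at pH 7.4 (a higher number here means that the compound crosses the layer faster, a lower number that the compound crosses the layer more slowly), compound 1 gives 801 10^-6 cm/s, the higher of the two numbers; compound 2 gives 640 10^-6 cm/s, and the step of a 1.3-fold lower number from compound 1 to compound 2 (0.10 log units; within the scatter) lies within the scatter, so the two are not distinguished.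

Compound 3 `Cc1cc(NC(=O)Nc2ccc(N)cc2)c2ccccc2n1` is not yet measured. Its change from compound 1 is amino in place of fluoro on an aromatic carbon, read one bond further out as 4-fluorophenyl to 4-aminophenyl. Going by the values given here, no measured step covers this change: the single known step, a 1.3-fold lower number from compound 1 to compound 2 (0.10 log units; within the scatter), concerns fluoro in place of hydrogen and is itself within the scatter, so it carries no direction for compound 3. The expectation rests on the change alone, where a fluoro leaves and a group with one hydrogen-bond donor and one acceptor enters.

Compound 3 is expected at 350 10^-6 cm/s, with a range of 150 10^-6 cm/s to 700 10^-6 cm/s, a step of a 2.3-fold lower number from compound 1 to compound 3 (0.36 log units; beyond the scatter) that is expected to be lower, beyond the scatter.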

Compound 3, apparent permeability: 530 10^-6 cm/s
Estimate against measurement, compound 3: 1.5-fold (0.18 log units) below; low and high end bracket the measured number.
By their numbers in this assay, from the lowest: compounds 3, 2 and 1 (each within the scatter of the next).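

In this assay, amino in place of fluoro on the aromatic carbon para to a large group gives a 1.5-fold lower number from compound 1 to compound 3 (0.18 log units; within the scatter), so the read-out does not separate these two compounds. Compound 1 and compound 2 showed only the addition of a fluoro; this step shows an exchange at the position itself, in which the entering amino carries a hydrogen-bond donor and a hydrogen-bond acceptor and the leaving fluoro carries neither, with no step beyond the scatter in this read-out. No accompanying data bear on this result.

On these data alone, whether a carboxylic acid, a methoxy group or a longer chain at the same position would also stay within the scatter of compound 1 in this assay remains open. Also open is whether a dimethylamino group would read like the amino group, since only the unsubstituted amine is shown here.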